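A few compounds are considered here, and "the series" means these few. Any claim that something is new, unique, unknown or untested is made for them only; others in the source may bear on it.

Measured in an ADME assay on HepG2 2.2.15 cells (Homo sapiens) for cytotoxicity; a higher number here means that more compound is tolerated, a lower number that less compound is tolerated:
- compound 1 `CC(=O)NCC(=O)OCCc1c(-c2ccccc2Cl)c2cc(Cl)ccc2[nH]c1=O`: 110000 nM
- compound 2 `O=C(OCCc1c(-c2ccccc2Cl)c2cc(Cl)ccc2[nH]c1=O)C1CCCC1`: 46000 nM
- compound 3 `O=C(OCCc1c(-c2ccccc2Cl)c2cc(Cl)ccc2[nH]c1=O)c1ccccc1`: 43000 nM

Compound 3 sits at the low end of these three numbers, a place it shares with compound 2. Next comes compound 4 `O=C(OCCc1c(-c2ccccc2Cl)c2cc(Cl)ccc2[nH]c1=O)c1cccnc1`, with pyridin-3-yl in place of phenyl on a carbonyl carbon.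

Two measured steps changed the group at this carbonyl carbon. One was modest: a 2.6-fold lower number from compound 1 to compound 3 (0.41 log units; beyond the scatter). The other stayed within the scatter: a 1.1-fold lower number from compound 2 to compound 3 (0.03 log units; within the scatter). Going by the values given here, neither introduces a pyridin-3-yl group, so the series offers no direct precedent. No change beyond the scatter is therefore expected in this assay. The expected change is a 1.2-fold higher number from compound 3 to compound 4 (0.07 log units; within the scatter). Compound 4 is estimated at 50000 nM, with an expected range of 25000 nM to 100000 nM.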

Compound 4, half-maximal cytotoxic concentration: 170000 nM
For compound 4 the middle estimate is 3.4-fold (0.53 log units) below the measured one, and the stated range ends below it.
By their numbers in this assay, from the lowest: compounds 3 and 2 (each within the scatter of the next); then compounds 1 and 4 (each within the scatter of the next).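

In this assay, a single ring nitrogen separates two otherwise matched six-membered aromatic groups on this carbonyl carbon: a 4.0-fold higher number from compound 3 to compound 4 (0.60 log units; beyond the scatter). The change from cyclopentyl gives a 3.7-fold higher number from compound 2 to compound 4 (0.57 log units; beyond the scatter), whereas the change from acetamidomethyl gives a 1.5-fold higher number from compound 1 to compound 4 (0.19 log units; within the scatter), so the two nitrogen-bearing groups stand together, apart from the two carbon-only groups. No supporting measurement accounts for this separation.

From the compounds shown here alone, whether pyridin-2-yl or pyridin-4-yl would match pyridin-3-yl at this carbonyl carbon remains open. So does whether a simple amine on the phenyl group would give a similar step.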